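Swapping 3,5-dibromo-2-hydroxyphenyl for thiophen-2-yl

The source may hold more compounds than are shown below. What is called first, only, known or untested is meant among the compounds shown, and "the series" means these compounds.

In a functional assay on SW 1116 cells (Homo sapiens) for cytotoxicity, read by MTT assay, with a stated time of 48 h (on this read-out higher numbers stand for weaker inhibition and lower numbers for stronger inhibition), compound 1 (`COc1cccc(/C=N/NC(=O)CSc2nnc(-c3ccncc3)o2)c1`) gives 16500 nM, compound 2 (`O=C(CSc1nnc(-c2ccncc2)o1)N/N=C/c1ccccc1F`) gives 21500 nM and compound 3 (`O=C(CSc1nnc(-c2ccncc2)o1)N/N=C/c1cc(Br)cc(Br)c1O`) gives 8570 nM. For the measured compounds named here, compound 3 stands at the low end of these numbers, but only one of its two steps clears the scatter: a 2.5-fold lower number from compound 2 to compound 3 (0.40 log units; beyond the scatter), whereas a 1.9-fold lower number from compound 1 to compound 3 (0.28 log units; within the scatter). Compound 4 (`O=C(CSc1nnc(-c2ccncc2)o1)N/N=C/c1cccs1`) differs from compound 3 as follows: thiophen-2-yl in place of 3,5-dibromo-2-hydroxyphenyl on a carbon with a double bond to nitrogen. Going by the values given here, no thiophen-2-yl compound has been measured, so the guides are those two steps and a 1.3-fold higher number from compound 1 to compound 2 (0.11 log units; within the scatter). Both groups without the bromines sit higher than compound 3, so a modest rise is expected. The estimated change is a 2.0-fold higher number from compound 3 to compound 4 (0.30 log units; within the scatter). For compound 4 the expected value is 17000 nM, within an estimated range of 8000 nM to 36000 nM.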

Compound 4, half-maximal inhibitory concentration: 24900 nM
Compound 4: middle estimate off by 1.5-fold (0.17 log units), on the low side; the range from low to high includes it.
By their numbers in this assay, from the lowest: compounds 3, 1, 2 and 4 (each within the scatter of the next, the first and the last beyond it).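

In this assay, for the compounds shown here, thiophen-2-yl on this carbon gives a clear rise against 3,5-dibromo-2-hydroxyphenyl, with a 2.9-fold higher number from compound 3 to compound 4 (0.46 log units; beyond the scatter) as the largest step so far. The steps of a 1.2-fold higher number from compound 2 to compound 4 (0.06 log units; within the scatter) and a 1.5-fold higher number from compound 1 to compound 4 (0.18 log units; within the scatter) leave the five-membered ring level with 2-fluorophenyl and 3-methoxyphenyl, so a sulfur-containing ring shows no separation from those two phenyl groups. Nothing available accounts for the gap to compound 3. The compounds shown do not separate the two bromines from the hydroxyl of compound 3. On these data alone, how a dimethylamino group or a carboxylic acid would fare at this position also remains open.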